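The compounds below may be only part of what the source reports. "The series", "measured", "known", "first", "only" and "open" are said of these compounds alone.

In an ADME assay on HEK293 cells (Homo sapiens) for cytotoxicity, with a stated time of 72 h (a higher number here means that more compound is needed for the effect, a lower number that less compound is needed), the three measured compounds stand as follows:

Compound 1 `C=C[C@@](C)(/C=C/c1ccc(OS(=O)(=O)C(F)(F)F)cc1)CCC=C(C)C` gives > 36600 nM.
Compound 2 `C=C[C@@](C)(/C=C/c1ccc(Nc2ccccc2)cc1)CCC=C(C)C` gives > 36600 nM.
Compound 3 `C=C[C@@](C)(/C=C/c1ccc(Nc2ccc(OC(F)(F)F)cc2)cc1)CCC=C(C)C` gives > 36600 nM.

For compound 1 this value is a limit of the assay, not a number. For compound 2 it is likewise a limit. For compound 3 it is a limit as well. Compound 2 therefore stands at the limit, and the two other values shown stand at the same limit; no ordering among the three can be read.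

Compound 4 `C=C[C@@](C)(/C=C/c1ccc(Nc2c(F)cc(F)cc2F)cc1)CCC=C(C)C` differs from compound 2 in one place: 2,4,6-trifluorophenyl in place of phenyl on a nitrogen on an aromatic ring. The two measured steps that bear on this change are a step that the two limits leave unreadable from compound 1 to compound 2 and a step that the two limits leave unreadable from compound 2 to compound 3; neither has a readable size, because of the limit of > 36600 nM in this assay, at which 3 of the 3 values shown sit. Among the measured compounds shown here, nothing among the measured compounds shows that a change on this side of the core moves the read-out off the limit in either direction. The expected step from compound 2 to compound 4 in this assay is therefore a step that the limit leaves unreadable from compound 2 to compound 4, with no direction beyond the scatter. Compound 4 is estimated to give 50000 nM in this assay, within a range from 18000 nM to 150000 nM, most likely reported again only as a limit.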

Compound 4, half-maximal effective concentration: > 36600 nM
Compound 4: only a limit was reported (the forecaster's own chance of this, stated with the estimate: 80%); the middle value is on the limit's open side.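

The result for compound 4 in this assay is a limit and not a number, as is the result for compound 2, so no step between compound 2 and compound 4 can be read: the limit of > 36600 nM in this assay, at which 4 of the 4 values shown sit.

The compounds shown leave open whether any change on the shared core brings the read-out to a readable number, and how these compounds order among themselves.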